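Cytotoxicity series: 3-hydroxyphenyl replaces 2,4-dimethoxypyrimidin-5-yl

The compounds below may be only part of what the source reports. "The series", "measured", "known", "first", "only" and "open" are said of these compounds alone.

Compound 3 `CCOC(=O)CCCCCOc1cccc(CN(C(=O)c2ccc(-c3cnc(OC)nc3OC)cc2)C(C)C)c1` stands only at a limit in an ADME assay on HEK293 cells (Homo sapiens) for cytotoxicity, read by CellTiter-Glo and resazurin assay, with a stated time of 72 h; a lower number here means that less compound is needed, a higher number that more compound is needed for the effect: compound 3 gives > 26000 nM, a limit of the assay rather than a number. Compound 1 `CC(=O)Nc1cccc(-c2ccc(C(=O)N(Cc3cccc(OCCCCCC(=O)O)c3)C(C)C)cc2)c1` also returns a limit, with > 26000 nM. Compound 2 `CC(C)N(Cc1cccc(OCCCCCC(=O)O)c1)C(=O)c1ccc(-c2cccc(OCc3ccccc3)c2)cc1` likewise sits at a limit, giving > 26000 nM. For the measured compounds named here, the one step between measured compounds, a step that the two limits leave unreadable from compound 1 to compound 2, cannot be read because both ends rest on the limit (the limit of > 26000 nM in this assay, at which 3 of the 3 values shown sit).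

Compound 4 `CCOC(=O)CCCCCOc1cccc(CN(C(=O)c2ccc(-c3cccc(O)c3)cc2)C(C)C)c1` differs from compound 3 in one place: 3-hydroxyphenyl in place of 2,4-dimethoxypyrimidin-5-yl on an aromatic carbon. Going by the values given here, no measured step bears on this change; the single step available is unreadable, so its size gives no guidance. All three values shown sit at the same limit, and nothing in the data points toward a move off it.

Compound 4 is therefore expected to remain at the limit, with an estimate of 50000 nM in this assay, its range running from 20000 nM to 200000 nM. The expected step that the limit leaves unreadable from compound 3 to compound 4 is estimated as none beyond the scatter, most likely hidden under the limit.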

Compound 4, half-maximal effective concentration: > 26000 nM
Compound 4 was reported as a limit; the forecaster's own chance of this, stated with the estimate: 85%; the middle value does not contradict the limit.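

The change from compound 3 to compound 4 gives no readable step, because both ends rest on a limit: the limit of > 26000 nM in this assay, at which 4 of the 4 values shown sit.

The compounds shown leave open whether any change to the shared core moves a value off this limit in this assay.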